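A few compounds are considered here, and "the series" means these few. Any claim that something is new, unique, unknown or untested is made for them only; others in the source may bear on it.

Measured in a functional assay on HepG2 cells (Homo sapiens) for cytotoxicity, read by MTT assay, with a stated time of 72 h; on this read-out higher numbers stand for weaker inhibition and lower numbers for stronger inhibition:

- compound 1 `Nc1ccccc1NC(=O)c1ccc(NC(=S)NCc2ccc(Cl)nc2)cc1` gives 19000 nM
- compound 2 `Nc1ccccc1NC(=O)c1ccc(CNC(=O)c2cc3cnccc3[nH]2)cc1` gives 1700 nM
- compound 3 `Nc1ccccc1NC(=O)c1ccc(Cn2cc(-c3ccc(NC(=O)NCc4cccnc4)cc3)nn2)cc1` gives 8100 nM

Among these three, compound 1 has the highest number, 19000 nM, which makes it the weakest inhibitor of the set in this assay. The nearest neighbour, compound 3 at 8100 nM, already lies clearly lower, and compound 2 at 1700 nM lies lower still.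

The next compound to test is compound 4 `Nc1ccccc1NC(=O)c1ccc(NC(=S)NCc2cccc(Cl)c2)cc1`. It differs from compound 1 in one place: 3-chlorophenyl in place of 6-chloropyridin-3-yl on a saturated chain carbon bound to an amide-type nitrogen. Put simply, this is 3-chlorophenyl in place of 6-chloropyridin-3-yl on a saturated chain carbon bound to an amide-type nitrogen.

Going by the values given here, no two measured compounds differ by a single change, so the data offer no direct guide to the effect of this swap. Both groups are chlorine-bearing six-membered aromatic rings, and the rest of the molecule stays the same, so only a modest shift seems reasonable. The expected change is a 1.7-fold lower number from compound 1 to compound 4 (0.24 log units; within the scatter), towards a slightly lower number and probably not beyond the usual scatter. For compound 4 the estimated value is 11000 nM, with an expected range from 4000 nM to 30000 nM.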

Compound 4, half-maximal inhibitory concentration: 2600 nM
Beside the measured number, compound 4's estimate is 4.2-fold (0.63 log units) above it; the whole stated range lies above it.
By their numbers in this assay, from the lowest: compounds 2 and 4 (each within the scatter of the next); then compound 3; then compound 1.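

In this assay, 3-chlorophenyl in place of 6-chloropyridin-3-yl gives a 7.3-fold lower number from compound 1 to compound 4 (0.86 log units; beyond the scatter), a step beyond the scatter. Going by these compounds alone, this is the first sign that the ring on this saturated chain carbon bound to an amide-type nitrogen matters to the read-out, even though the two groups have the same count of heavy atoms and the rest of the molecule stays the same. What is counted to differ is small, a ring nitrogen with its one hydrogen-bond acceptor giving way to carbon, but no measurement shown here accounts for the size of the step.

The swap also changes the name-given place of the chlorine, so this one pair cannot say whether the ring nitrogen or the chlorine placement carries the difference, and it cannot say whether the same swap would act alike on any other part of the series. A plain phenyl, a 4-chlorophenyl or a 3-methoxyphenyl on the same carbon, or a two-carbon ethyl chain in place of the single carbon that links the ring to the nitrogen, would each help to separate these possibilities.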